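Adding a methoxy to compound 1

The source may report more compounds than this note shows. Statements on the series, on what has been measured and on what is new or still open speak of the compounds shown alone.

Among the compounds with values here, in a functional assay on MDA-MB-231 cells (Homo sapiens) for antiproliferative activity, read by XTT assay (a higher number here means a weaker inhibitor, a lower number a stronger inhibitor), compound 1 `O=c1c(Cc2coc3cccc(OCC4CCCCC4)c3c2=O)coc2ccccc12` gives 4110 nM, the only exact number so far. Compound 2 `CC(C)COc1cccc2occ(Cc3coc4ccccc4c3=O)c(=O)c12` reaches only a limit of the assay, > 10000 nM. Compound 3 `COc1ccc2c(=O)c(Cc3coc4cccc(OCC5CCCCC5)c4c3=O)coc2c1` keeps the cyclohexyl group of compound 1 and differs from it by methoxy in place of hydrogen on an aromatic carbon. Within the data shown here, the only measured step, an at least 2.4-fold higher number from compound 1 to compound 2 (0.38 log units; beyond the scatter), places isopropyl in place of cyclohexyl, so it bears only indirectly on the new change. Among the measured compounds shown here, it concerns a different place in the molecule, and no measured step tests a methoxy. Compound 3 retains the cyclohexyl group lost in that step, so no shift beyond the scatter is expected in this assay, and neither direction is favoured. The expected change is a 1.1-fold higher number from compound 1 to compound 3 (0.04 log units; within the scatter). For compound 3 the estimated value is 4500 nM, with an expected range of 1500 nM to 10000 nM.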

Compound 3, half-maximal inhibitory concentration: 1200 nM
Estimate against measurement, compound 3: 3.8-fold (0.57 log units) above; the measured number lies below the stated range.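

Methoxy in place of hydrogen gives, in this assay, a 3.4-fold lower number from compound 1 to compound 3 (0.53 log units; beyond the scatter), so this aromatic carbon, meta to a fused ring and para to a fused ring, is a place where a change moves the number in the direction of a stronger inhibitor. The earlier step changed only the cyclohexyl group and ended at a limit of the assay, so it showed one way to lose activity but none to gain it. Nothing given here accounts for the shift seen with the methoxy.

On these data alone, it remains open whether this gain belongs to methoxy itself or would also appear with a hydroxyl, a fluorine or a longer ether chain such as ethoxy at this carbon. As far as these compounds go, it is equally open whether a methoxy on the other aromatic carbons of this ring would give the same result, or whether the gain would hold with a group other than the cyclohexyl group at the far end of the molecule.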